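The compounds below may be only part of what the source reports. "The series", "measured", "known", "first", "only" and "open" are said of these compounds alone.

Compound 1 `Cc1c(CN2CCCC2)cc(-c2ccc(Cl)cc2)n1Nc1ccnc2cc(Cl)ccc12` and compound 2 `CCN(CC)Cc1cc(-c2ccc(F)cc2)n(Nc2ccnc3cc(Cl)ccc23)c1C` have both been tested in an ADME assay on HMEC-1 cells (Homo sapiens) for cytotoxicity, read by MTT assay, with a stated time of 72 h; on this read-out higher numbers stand for lower toxicity in this test and lower numbers for higher toxicity in this test. Compound 1 gives 7180 nM, while compound 2 gives 18600 nM, the higher of the two numbers; the two compounds differ in two places at once, so their gap cannot be laid to a single change. Compound 3 `Cc1c(CN2CCCC2)cc(-c2ccc(F)cc2)n1Nc1ccnc2cc(Cl)ccc12` remains unmeasured; it carries pyrrolidin-1-yl in place of diethylamino on a saturated chain carbon bound to an aromatic carbon. Without a measured single-change comparison to guide this step, only a modest shift is expected, about a 1.4-fold lower number from compound 2 to compound 3 (0.16 log units; within the scatter) in this assay, hardly beyond the usual scatter. Compound 3 is therefore estimated at 13000 nM, between 5500 nM and 30000 nM.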

Compound 3, half-maximal cytotoxic concentration: 10100 nM
Compound 3: the middle estimate sits 1.3-fold (0.11 log units) above what was measured; measured number inside the range.
By their numbers in this assay, from the lowest: compounds 1, 3 and 2 (each within the scatter of the next, the first and the last beyond it).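

In this assay, pyrrolidin-1-yl and diethylamino on a saturated chain carbon bound to an aromatic carbon are barely told apart, with a 1.8-fold lower number from compound 2 to compound 3 (0.27 log units; within the scatter) for this exchange. Fluoro in place of chloro on an aromatic carbon gives a 1.4-fold higher number from compound 1 to compound 3 (0.15 log units; within the scatter) and is equally unresolved, so neither single change accounts on its own for the clear gap between compound 1 and compound 2. No supporting measurement explains either step. From the compounds shown here alone, whether piperidin-1-yl or morpholin-4-yl on that chain, or bromo on that aromatic carbon, would shift the number beyond the scatter remains open.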